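The source may report more compounds than this note shows. Statements on the series, on what has been measured and on what is new or still open speak of the compounds shown alone.

- compound 1 `NC(=O)c1ccc(-c2cnc(N)c(-c3ccc(C(F)(F)F)cc3)n2)cc1`: 80000 nM
- compound 2 `Nc1ccc(-c2nc(-c3ccc(S(=O)(=O)C4CC4)cc3)cnc2N)cn1`: 212000 nM

Within the data shown here, only two compounds have been measured so far in a physicochemical assay for solubility, read by HPLC, using the shake flask method, with a stated time of 2 h, at pH 2; a lower number here means a less soluble compound, a higher number a more soluble compound. Compound 1 stands lowest of the two at 80000 nM, and compound 2 reads higher at 212000 nM, a gap beyond the usual scatter. These two compounds differ in more than one place, so their gap does not size any single change.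

The next compound is compound 3 `Nc1ncc(-c2ccc(C(=O)N3CC[C@H](O)C3)cc2)nc1-c1ccc(C(F)(F)F)cc1`. Relative to compound 1, the change is 3-hydroxypyrrolidin-1-yl in place of amino on a carbonyl carbon, which reads carbamoyl to (3-hydroxypyrrolidin-1-yl)carbonyl. The rest of the structure stays the same.

Among the measured compounds shown here, no measured pair shows this change, so the expectation is only a judgement and carries a wide range. A small upward step in this assay is expected, a 1.8-fold higher number from compound 1 to compound 3 (0.24 log units; within the scatter), and it may not clear the scatter. For compound 3 the estimated value is 140000 nM, with an expected range of 50000 nM to 380000 nM.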

Compound 3, solubility: 93000 nM
Compound 3: the middle estimate sits 1.5-fold (0.18 log units) above what was measured; the measured number falls inside the stated range.
By their numbers in this assay, from the lowest: compounds 1 and 3 (each within the scatter of the next); then compound 2.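

In this assay, the series now has its first comparison of compounds that differ in one place: a 1.2-fold higher number from compound 1 to compound 3 (0.07 log units; within the scatter), with 3-hydroxypyrrolidin-1-yl in place of amino on a carbonyl carbon, so this read-out does not separate compound 1 from compound 3. At this position, then, the carbamoyl can give way to (3-hydroxypyrrolidin-1-yl)carbonyl, with its five-membered non-aromatic ring and defined stereocentre, without a step that clears the scatter. Nothing measured here speaks to a cause for this reading.

Open, going by these compounds, is whether a plain pyrrolidin-1-yl on the same carbonyl carbon, or the opposite stereocentre of the 3-hydroxypyrrolidin-1-yl group, would also stay within the scatter of compound 1 in this assay. Also open, on these data alone, is whether a group carrying an amine, such as piperazin-1-yl, or a carboxylic acid at this place would give a step beyond the scatter.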